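The source may report more compounds than this note shows. Statements on the series, on what has been measured and on what is new or still open speak of the compounds shown alone.

Four compounds share one core and differ only in the aromatic group on the side chain: compound 1 `OC[C@H]1O[C@@H](n2cnc3c(NCc4cccc(F)c4)ncnc32)[C@H](O)[C@@H]1O`, compound 2 `OC[C@H]1O[C@@H](n2cnc3c(NCc4ccccc4Cl)ncnc32)[C@H](O)[C@@H]1O`, compound 3 `COc1ccc(CNc2ncnc3c2ncn3[C@@H]2O[C@H](CO)[C@@H](O)[C@H]2O)c(OC)c1` and compound 4 `OC[C@H]1O[C@@H](n2cnc3c(NCc4c(F)ccc(F)c4F)ncnc32)[C@H](O)[C@@H]1O`. In a functional assay on B16 cells (Mus musculus) for antiproliferative activity, with a stated time of 72 h (on this read-out lower numbers stand for stronger inhibition and higher numbers for weaker inhibition), compound 2 gives > 166000 nM, which is a limit and not a number. Compound 1 has only the entry "not determined" (no result reported). Compound 3 likewise has only the entry "not determined" (no result reported), so it offers no number to start from. Going on to compound 4 brings a single structural change: 2,3,6-trifluorophenyl in place of 2,4-dimethoxyphenyl on a saturated chain carbon bound to a nitrogen on an aromatic ring. Within the data shown here, no pair of measured compounds shows what such a swap does, so the size of this step cannot be read from the data. Among the measured compounds shown here, the only guide is compound 2, whose result of > 166000 nM points to very weak inhibition in this family. The expectation in this assay is therefore no clear gain in strength, with compound 4 staying in that same weak region. For compound 4 the estimated half-maximal inhibitory concentration is 170000 nM, with an expected range of 80000 nM to 350000 nM.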

Compound 4, half-maximal inhibitory concentration: > 166000 nM
Compound 4: only a limit was reported; the forecaster's own chance of this, stated with the estimate: 75%; the middle value does not contradict the limit.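

No step can be read from compound 2 to compound 4, because both results are limits and not numbers: the limit of > 166000 nM in this assay, at which 2 of the 4 values shown sit.

The compounds shown leave open whether any of these aromatic groups on the shared core gives a true number in this assay, and where compound 1 and compound 3 stand.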